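The source may report more compounds than this note shows. Statements on the series, on what has been measured and on what is new or still open speak of the compounds shown alone.

Three compounds share one core and differ in a single group. In a functional assay on L1210 cells (Mus musculus) for inhibition, read by cell counting, with a stated time of 2 days (a lower number here means a stronger inhibitor, a higher number a weaker inhibitor), compound 1 `C=C(Br)C(=O)Nc1cccc(-c2cn3nc(-c4ccc(CC)cc4)sc3n2)c1` gives 2200 nM, compound 2 `C=C(Br)C(=O)Nc1cccc(-c2cn3nc(-c4ccc(F)cc4)sc3n2)c1` gives 250 nM, and compound 3 `C=C(Br)C(=O)Nc1cccc(-c2cn3nc(Cc4ccccc4)sc3n2)c1` gives 3000 nM, the top of the three numbers, though only within the scatter of compound 1 and clearly beyond compound 2, as a 12-fold higher number from compound 2 to compound 3 (1.08 log units; beyond the scatter) shows. Compound 4 `C=C(Br)C(=O)Nc1cccc(-c2cn3nc(-c4ccc(OCC)cc4)sc3n2)c1` carries 4-ethoxyphenyl in place of benzyl on an aromatic carbon. Within the data shown here, two measured steps bear on this change: a 1.4-fold higher number from compound 1 to compound 3 (0.13 log units; within the scatter) was within the scatter, whereas the step from compound 2 to compound 3 was large. Swapping benzyl for another aromatic group has thus ranged from no change to a large fall in number, so a moderate fall is expected here. Compound 4 is estimated at 1000 nM, between 300 nM and 3500 nM, which would be expected to mean a 3.0-fold lower number from compound 3 to compound 4 (0.48 log units; beyond the scatter).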

Compound 4, half-maximal inhibitory concentration: 790 nM
For compound 4 the middle estimate is 1.3-fold (0.10 log units) above the measured one; low and high end bracket the measured number.
By their numbers in this assay, from the lowest: compound 2; then compound 4; then compounds 1 and 3 (each within the scatter of the next).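

With a 3.8-fold lower number from compound 3 to compound 4 (0.58 log units; beyond the scatter) in this assay as a third replacement of benzyl, the result lies between the two earlier ones, so the outcome depends on what the new aromatic ring carries. Ethoxy also falls between the other two groups on that ring, with a 2.8-fold lower number from compound 1 to compound 4 (0.44 log units; beyond the scatter) when it replaces ethyl and a 3.2-fold higher number from compound 2 to compound 4 (0.50 log units; beyond the scatter) when it replaces fluoro. Nothing available here explains this order.

Still open, on these data alone, is how an amine or a carboxylic acid in place of fluoro would compare with compound 2. As far as these compounds go, it is also open how a chain longer than ethoxy would move the number.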